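Bromo ester to free acid: working notes

The compounds below may be only part of what the source reports. "The series", "measured", "known", "first", "only" and "open" are said of these compounds alone.

Measured so far in a functional assay on A549 cells (Homo sapiens) for cytotoxicity, read by CCK-8 assay, with a stated time of 72 h; a lower number here means a stronger inhibitor, a higher number a weaker inhibitor:
Compound 1 `COC(=O)CC1CNC(=O)c2cccn21` gives > 200000 nM, a limit of the assay and not a number.
Compound 2 `COC(=O)CC1CNC(=O)c2ccc(Br)n21` gives 65000 nM.

Going by the values given here, compound 2 holds the only true number so far. For compound 1 the result is the limit of > 200000 nM in this assay, at which 1 of the 2 values shown sits.

Compound 3 `O=C(O)CC1CNC(=O)c2ccc(Br)n21` keeps the bromo group of compound 2 and has hydrogen in place of methyl on an oxygen next to a carbonyl group, which turns methoxycarbonyl to carboxy (hydrogen in place of methyl on an oxygen next to a carbonyl group).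

Among the compounds with values here, the only measured step is an at least 3.0-fold lower number from compound 1 to compound 2 (0.48 log units; beyond the scatter). It is a bromo in place of hydrogen on an aromatic carbon, so it does not test the methoxycarbonyl group. Within the data shown here, no measured step changes that group, and the size of the new step rests on little. A modest step towards a higher number in this assay is expected, and a report that gives only a limit is quite possible. The expected change is a 1.8-fold higher number from compound 2 to compound 3 (0.27 log units; within the scatter). For compound 3 the estimated value is 120000 nM, with an expected range of 50000 nM to 300000 nM.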

Compound 3, half-maximal inhibitory concentration: > 200000 nM
Compound 3 ended at the assay's limit; the forecaster's own chance of this, stated with the estimate: 45%; middle value at least 1.6-fold (0.22 log units) away from the limit.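

In this assay, the methoxycarbonyl group now has a measured step of its own: with the bromo group kept, methoxycarbonyl to carboxy gives an at least 3.0-fold higher number from compound 2 to compound 3 (0.48 log units; beyond the scatter). The earlier step, an at least 3.0-fold lower number from compound 1 to compound 2 (0.48 log units; beyond the scatter), tested only the bromo group, whereas this one shows that the bromo group alone does not secure a true number, and that the number for compound 2 also depends on the methyl on the oxygen next to the carbonyl group. Compound 2 therefore remains the only compound in the series with a true number, and the other results are limits: the limit of > 200000 nM in this assay, at which 2 of the 3 values shown sit.

Going by these compounds, the full size of the new step stays open, as the result for compound 3 is a limit of the assay and not a number. Also open, on these data alone, is how the series responds to other groups in place of methoxycarbonyl, such as ethoxycarbonyl or a primary amide, or to chloro in place of bromo, and whether any of them gives a lower number than compound 2 does.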